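The compounds below may be only part of what the source reports. "The series", "measured", "known", "first", "only" and "open" are said of these compounds alone.

Of the compounds shown here, three with a shared core have been measured in a functional assay on the whole organism (stomach) for inhibition, with Canis familiaris (Canis lupus familiaris) as the target, at a dose of 2 mg/kg by the intravenous route; on this read-out lower numbers stand for a weaker effect and higher numbers for a stronger effect at the one dose given. Compound 1 `[C-]#[N+]Cc1c(C)nc2c(OCc3ccccc3)cccn12` gives 94%, compound 2 `Cc1nc2c(OCc3ccccc3)cccn2c1CO` gives 80%, and compound 3 `CC(=O)OCc1c(C)nc2c(OCc3ccccc3)cccn12` gives 54%. Compound 3 therefore stands lowest of the three, beyond the scatter below both others, and the step of a number 26 percentage points lower from compound 2 to compound 3 (beyond the scatter) marks the change from a free hydroxyl to its acetyl ester.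

Compound 4 `Cc1nc2c(OCc3ccccc3)cccn2c1COC(=O)C(C)(C)C` differs from compound 3 in one place: tert-butyl in place of methyl on a carbonyl carbon. Read one bond further out, this is acetyl to (tert-butyl)carbonyl. Among the measured compounds shown here, none of the measured steps exchanges one acyl group for another, so they bear only indirectly. The step of a number 26 percentage points lower from compound 2 to compound 3 (beyond the scatter) shows that adding acetyl to the oxygen lowered the read-out modestly, and a number 40 percentage points lower from compound 1 to compound 3 (beyond the scatter) was a large drop. Since the ester group is retained and only made larger, a small step is expected, most likely downward, though possibly none beyond the scatter, so the expected step is a number 9 percentage points lower from compound 3 to compound 4 (within the scatter). Compound 4 is thus estimated at 45%, within a range from 20% to 70%.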

Compound 4, a percentage reported as inhibition, in the whole organism at one dose (the size of the read-out at that dose, not a potency): 43%
The estimate for compound 4 lay 2 percentage points above the measured number, and the stated range covers the measured number.
By their numbers in this assay, from the lowest: compound 4; then compound 3; then compound 2; then compound 1.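

In this assay, enlarging the acyl group from acetyl to (tert-butyl)carbonyl gives a number 11 percentage points lower from compound 3 to compound 4 (beyond the scatter), so the read-out responds to what sits on the carbonyl carbon, not only to whether an ester is present. Placing (tert-butyl)carbonyl on the oxygen of the free hydroxyl gives a number 37 percentage points lower from compound 2 to compound 4 (beyond the scatter), and the full change from the group carried by compound 1 gives a number 51 percentage points lower from compound 1 to compound 4 (beyond the scatter), the largest step among these compounds. No measurement here accounts for these falls.

On these data alone, it remains open where an ester with a longer straight chain, such as butanoyl, or a benzoyl ester would fall relative to these two esters. An amine or a carboxylic acid on the same saturated chain carbon, and the effect of these compounds at other doses, also remain open.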